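Benzyloxy in place of butoxy: expectation for compound 3

The source may report more compounds than this note shows. Statements on the series, on what has been measured and on what is new or still open speak of the compounds shown alone.

Compound 1 `CCCCOc1cc(C(C)(C)C)ccc1C/N=C(\S)NCc1ccc(NS(C)(=O)=O)cc1` and compound 2 `CCCCCOc1cc(C(C)(C)C)ccc1C/N=C(\S)NCc1ccc(NS(C)(=O)=O)cc1` share one core and differ only in the chain on the oxygen on the aromatic ring. In a functional assay for inhibition of Vanilloid receptor (Rattus norvegicus) (on this read-out higher numbers stand for weaker inhibition and lower numbers for stronger inhibition), compound 1 gives 60 nM. In this assay compound 2 gives 70 nM. Compound 1 holds the lowest of the two numbers, but a 1.2-fold higher number from compound 1 to compound 2 (0.07 log units; within the scatter), so the two compounds cannot be told apart on this assay.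

Compound 3 `CC(C)(C)c1ccc(C/N=C(\S)NCc2ccc(NS(C)(=O)=O)cc2)c(OCc2ccccc2)c1` has not yet been measured. It differs from compound 1 in one place: phenyl in place of propyl on a saturated chain carbon bound to an oxygen on an aromatic ring. Among the compounds with values here, the only measured step that touches this part of the molecule is a 1.2-fold higher number from compound 1 to compound 2 (0.07 log units; within the scatter), a lengthening of the chain that left this assay unchanged. Within the data shown here, exchanging propyl for phenyl is a larger change than adding a methyl, and no measured compound carries a ring in place of the chain, so the direction is open. On this evidence no step beyond the scatter is expected in this assay, though with wide uncertainty, and the expected step is no change at the digits printed from compound 1 to compound 3 (within the scatter). Compound 3 is estimated at 60 nM in this assay, with a range from 20 nM to 180 nM.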

Compound 3, half-maximal inhibitory concentration: 770 nM
Compound 3: the middle estimate sits 13-fold (1.11 log units) below what was measured, and the stated range ends below it.
By their numbers in this assay, from the lowest: compounds 1 and 2 (each within the scatter of the next); then compound 3.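

In this assay, the chain on the oxygen on the aromatic ring proves not to be freely variable: exchanging butyl for benzyl gives a 13-fold higher number from compound 1 to compound 3 (1.11 log units; beyond the scatter), and the exchange starting from the longer saturated chain gives an 11-fold higher number from compound 2 to compound 3 (1.04 log units; beyond the scatter). The same position showed no readable response to one added methyl, a 1.2-fold higher number from compound 1 to compound 2 (0.07 log units; within the scatter), so tolerance of a longer saturated chain does not extend to phenyl in place of propyl, and compound 3 is the weakest of the three inhibitors shown. The available data offer no explanation for this loss of inhibition.

The compounds shown leave open whether the loss belongs to the aromatic ring as such or to any ring at this place, a question that cyclohexyl in place of phenyl on the same saturated chain carbon would address. Also open, from the compounds shown here alone, is how far the saturated chain can grow before the number moves, as with a hexyl or octyl chain, and how a chain carrying an amine or a carboxylic acid would read out.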